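Swapping a thiazole for a methoxyphenyl on the piperidine

The compounds below may be only part of what the source reports. "The series", "measured", "known", "first", "only" and "open" are said of these compounds alone.

Compound 1 `O=C(NCN1CCC(c2cccc[n+]2[O-])CC1)c1ccccc1`: 532 nM
Compound 2 `Cc1cccc(NC(=O)CN2CCC(c3nccs3)CC2)c1`: 1 nM

Of the two compounds measured in a functional assay on HEK293 cells for agonist activity at D(4) dopamine receptor (Homo sapiens), read by FLIPR (a higher number here means that more compound is needed for the effect, a lower number that less compound is needed), compound 2 gives the lower number, and its gap to compound 1 lies beyond the scatter. Compound 3 `COc1ccccc1C1CCN(CC(=O)Nc2cccc(C)c2)CC1` keeps the shared core of compound 2 and differs only in one group: 2-methoxyphenyl in place of 1,3-thiazol-2-yl on a saturated ring carbon. Going by the values given here, no step of this kind has been measured, so the expectation rests on compound 2 alone. In this assay the step is expected to be a 4.0-fold higher number from compound 2 to compound 3 (0.60 log units; beyond the scatter), small and toward a higher number, yet staying within a few multiples of the scatter. Compound 3 is therefore expected to give 4 nM, with a range from 0.8 nM to 25 nM.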

Compound 3, half-maximal effective concentration: 420 nM
Estimate against measurement, compound 3: 110-fold (2.02 log units) below; measured number outside the range, above it.
By their numbers in this assay, from the lowest: compound 2; then compounds 3 and 1 (each within the scatter of the next).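

In this assay, replacing 1,3-thiazol-2-yl with 2-methoxyphenyl on the saturated ring carbon gives a 420-fold higher number from compound 2 to compound 3 (2.62 log units; beyond the scatter) and so shows that the number depends strongly on the group at this position. The earlier compounds shown here, which differ in more than one place, could not show this. Nothing at hand bears on why the step is so large.

The compounds shown leave open whether the step belongs to the six-membered ring of carbon or to its methoxy group. A plain phenyl, a pyridine or an oxazole at this place could help separate these.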